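One ring swap in a cytotoxicity series

The source may report more compounds than this note shows. Statements on the series, on what has been measured and on what is new or still open speak of the compounds shown alone.

Compound 1 (`CC(C)NCCOc1c(O)cc(O)c2c(=O)cc(-c3ccccc3)oc12`) has the entry "not determined" (no result reported) in a functional assay on A549 cells (Homo sapiens) for cytotoxicity, read by MTT assay, with a stated time of 48 h (on this read-out higher numbers stand for weaker inhibition and lower numbers for stronger inhibition), and so offers no comparison. Going by the values given here, compound 2 (`COc1c(OCCCCN2CCCC2)cc(O)c2c(=O)cc(-c3ccccc3)oc12`) gives 1530 nM there, the only number in the set, so it cannot yet be ranked against any other compound. Compound 3 (`COc1c(OCCCN2CCNCC2)cc(O)c2c(=O)cc(-c3ccccc3)oc12`) remains unmeasured. It differs from compound 2 on a saturated chain carbon, three bonds along the chain from an oxygen on an aromatic ring, where the change is piperazin-1-yl in place of (pyrrolidin-1-yl)methyl on a saturated chain carbon, three bonds along the chain from an oxygen on an aromatic ring and the rest of the structure stays the same. Cut one bond further out, this reads 4-(pyrrolidin-1-yl)butyl to 3-(piperazin-1-yl)propyl. Among the compounds with values here, no measured pair shows what such a change does in this assay, so the expectation is loose: a modest move toward weaker inhibition, perhaps not far beyond the scatter. The expected size of a 2.0-fold higher number from compound 2 to compound 3 (0.29 log units; within the scatter) is only an estimate. Compound 3 is estimated at 3000 nM, with an expected range from 1000 nM to 9000 nM in this test.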

Compound 3, half-maximal inhibitory concentration: 10100 nM
Estimate against measurement, compound 3: 3.4-fold (0.53 log units) below; the measured number lies above the stated range.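

This first measured pair shows that the position is sensitive in this assay: placing piperazin-1-yl where (pyrrolidin-1-yl)methyl stood gives a 6.6-fold higher number from compound 2 to compound 3 (0.82 log units; beyond the scatter) on the side of weaker inhibition. Read one bond further out, the change is 4-(pyrrolidin-1-yl)butyl to 3-(piperazin-1-yl)propyl, so the ring and the chain differ together and this single step belongs to the whole replacement, not to either part alone. No available evidence accounts for the step. The compounds shown do not separate the two parts, which would take a pairing with 3-(pyrrolidin-1-yl)propyl or 4-(piperazin-1-yl)butyl on the same core. They also leave open how a morpholine ring or a simple dimethylamino group at the end of the chain would read in this assay.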